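This account rests on a few compounds, and the source may have more. Where it says the series, first, only, none or still open, it means among the compounds named here.

Measured so far:
Compound 1 `CC1=CCC[C@](C)(CC/C(C)=C/CC2=C(O)C(=O)C=C(N[C@H](C(=O)O)[C@@H](C)O)C2=O)[C@@H]1C` — in an ADME assay on L1210 cells (Mus musculus) for cytotoxicity, with a stated time of 48 h (on this read-out lower numbers stand for stronger inhibition and higher numbers for weaker inhibition), compound 1 gives > 10 ug/mL, which is a limit of the assay.
Compound 2 `C=C1[C@H](C)CCC[C@]1(C)CC/C(C)=C/CC1=C(O)C(=O)C=C(N[C@H](C(=O)O)[C@@H](C)O)C1=O` — in this assay compound 2 gives > 10 ug/mL, likewise a limit of the assay.
Compound 3 `COC1=CC(=O)C(O)=C(C/C=C(\C)CC[C@@]2(C)CCC=C(C)[C@H]2C)C1=O` — in this assay compound 3 gives 2 ug/mL.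

Compound 2 therefore stands at the limit of > 10 ug/mL in this assay, at which 2 of the 3 values shown sit. Its step from compound 1 is a step that the two limits leave unreadable from compound 1 to compound 2, so the exchange of one ring-bearing group for the other cannot be judged from these numbers. Among the compounds with values here, the only readable step is an at least 5.0-fold lower number from compound 1 to compound 3 (0.69 log units; beyond the scatter), and it concerns a different part of the shared core, not the chain carbon at issue here.

Compound 4 `C=C1[C@H](C)CCC[C@]1(C)CC/C(C)=C/CC1=C(O)C(=O)C=C(N[C@H](C(=O)O)[C@H](C)O)C1=O` is the next compound. Relative to compound 2 the change is the two compounds have the same atoms and bonds and differ only in configuration as drawn: 1 of 5 stereo elements differ; a stereocentre at a saturated chain carbon is drawn R in compound 2 and S in compound 4. Within the data shown here, none of the measured steps involves a change of configuration, so no direct guide exists. Given that compound 2 sits at a limit and the skeleton is otherwise unchanged, the step is expected to be a step that the limit leaves unreadable from compound 2 to compound 4, with no shift beyond the scatter. Compound 4 is accordingly estimated at 15 ug/mL, within a range from 7 ug/mL to 40 ug/mL, and most probably the assay will again return only a limit.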

Compound 4, half-maximal inhibitory concentration: > 10 ug/mL
Compound 4: only a limit was reported (the forecaster's own chance of this, stated with the estimate: 80%); the middle value does not contradict the limit.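

Within the data shown here, compound 4 gives > 10 ug/mL in this assay, a limit of the assay, and compound 2 also sits at a limit, so no step between these two compounds can be read. The compounds shown leave open whether the change at that saturated chain carbon alters the read-out at all, as the only difference is this: the fact that compounds 2 and 4 differ only in the configuration as drawn.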